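Benzyl in Place of Dimethylphenyl on an Amide-Linked Core

The compounds below may be only part of what the source reports. "The series", "measured", "known", "first", "only" and "open" are said of these compounds alone.

Compound 1 `Cc1cccc(OCC(=O)Nc2nc(-c3ccccc3)n[nH]2)c1` and compound 2 `Cc1cc(C)cc(OCC(=O)Nc2nc(-c3ccccc3)n[nH]2)c1` share one core. In an assay on CHO cells for inhibition of adenosine receptor A1 (Homo sapiens), read by scintillation counting, with a stated time of 60 min (on this read-out lower numbers stand for stronger inhibition and higher numbers for weaker inhibition), compound 1 gives 2300 nM, and compound 2 gives 1600 nM. The step of a 1.4-fold lower number from compound 1 to compound 2 (0.16 log units; within the scatter) accompanies a methyl in place of hydrogen on an aromatic carbon. Within the data shown here, compound 2 stands at the lower of the two numbers so far, but that gap is within the scatter, so the two compounds cannot be told apart. Compound 3 `O=C(COCc1ccccc1)Nc1nc(-c2ccccc2)n[nH]1` differs from compound 2 by benzyl in place of 3,5-dimethylphenyl on an oxygen on a saturated carbon, the benzyl entering on an oxygen on a saturated carbon whose other neighbour is a saturated chain carbon. Among the measured compounds shown here, no measured step touches this part of the molecule; the one step known concerns a methyl on the aromatic ring and lay within the scatter, so it gives no direction. The expected step is therefore a 1.6-fold higher number from compound 2 to compound 3 (0.19 log units; within the scatter), little beyond the scatter. Compound 3 is estimated at 2500 nM, within a range from 800 nM to 8000 nM.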

Compound 3, inhibition constant: 8100 nM
Compound 3: middle estimate off by 3.2-fold (0.51 log units), on the low side, and the stated range ends below it.
By their numbers in this assay, from the lowest: compounds 2 and 1 (each within the scatter of the next); then compound 3.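

On an oxygen on a saturated carbon, the aromatic group proves to matter in this assay, which the methyl step within the scatter did not reveal. Benzyl in place of 3,5-dimethylphenyl gives a 5.1-fold higher number from compound 2 to compound 3 (0.70 log units; beyond the scatter), and benzyl in place of 3-methylphenyl gives a 3.5-fold higher number from compound 1 to compound 3 (0.55 log units; beyond the scatter), so both changes go in the same direction and both lie beyond the scatter. Nothing available explains this rise.

The benzyl group of compound 3 carries no methyl, so the compounds shown leave open how much of the rise goes with the added carbon and how much with the lost methyl groups, a question that plain phenyl or 3-methylbenzyl on this oxygen would address. Also open, as far as these compounds go, is how a longer chain, such as 2-phenylethyl, would read at this place.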